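A few compounds are considered here, and "the series" means these few. Any claim that something is new, unique, unknown or untested is made for them only; others in the source may bear on it.

Measured compounds:
Compound 1 `O=C([C@@H]1CCCN(S(=O)(=O)c2ccc(S(=O)(=O)N3CC[C@@H](O)C3)cc2)C1)N1CCC(F)(F)CC1`: 330 nM
Compound 2 `CCN(CC)S(=O)(=O)c1ccc(S(=O)(=O)N2CCC[C@@H](C(=O)N[C@@H]3CCOC3)C2)cc1`: 2270 nM
Compound 3 `CCN(CC)S(=O)(=O)c1ccc(S(=O)(=O)N2CCC[C@@H](C(=O)N3CCC(COC)CC3)C2)cc1`: 1360 nM

In a functional assay on BXPC-3 cells (Homo sapiens) for inhibition, read by MTT assay, with a stated time of 7 days (on this read-out higher numbers stand for weaker inhibition and lower numbers for stronger inhibition), compound 1 gives the lowest number of the three, and its gaps to compound 3 and to compound 2 both lie beyond the scatter, so compound 1 is the strongest inhibitor among the measured compounds. Compound 4 `O=C([C@@H]1CCCN(S(=O)(=O)c2ccc(S(=O)(=O)C3COC3)cc2)C1)N1CCC(F)(F)CC1` keeps the core of compound 1 and differs from it in one place: oxetan-3-yl in place of 3-hydroxypyrrolidin-1-yl on a sulfonyl sulfur. Among the measured compounds shown here, the only measured step, a 1.7-fold lower number from compound 2 to compound 3 (0.22 log units; within the scatter), changes the group on the carbonyl carbon rather than on the sulfonyl sulfur, so it does not bear on this change. For the measured compounds named here, no measured pair differs at the sulfonyl sulfur, and the effect of this change is therefore open; with nothing pointing in either direction, a step within the scatter is the plainest expectation, held with wide uncertainty. Compound 4 is expected to give 500 nM in this assay, within a range from 150 nM to 2000 nM. That estimate means an expected step of a 1.5-fold higher number from compound 1 to compound 4 (0.18 log units; within the scatter).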

Compound 4, half-maximal inhibitory concentration: 361 nM
The estimate for compound 4 lay 1.4-fold (0.14 log units) above the measured number; the measured number falls inside the stated range.
By their numbers in this assay, from the lowest: compounds 1 and 4 (each within the scatter of the next); then compounds 3 and 2 (each within the scatter of the next).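

In this assay the change on the sulfonyl sulfur gives a 1.1-fold higher number from compound 1 to compound 4 (0.04 log units; within the scatter) and so leaves the two compounds level. Among the compounds shown here, this is the first measured step at this place, and it shows that 3-hydroxypyrrolidin-1-yl, with its ring nitrogen, its hydrogen-bond donor and its defined stereocentre, can be replaced by oxetan-3-yl, which has none of these and fewer heavy atoms, with no step beyond the scatter. No measurement given here accounts for this result.

The compounds shown leave open whether an amine such as dimethylamino or a carboxylic acid on the sulfonyl sulfur would also keep the number level. Also open, from the compounds shown here alone, is whether this same replacement would read alike with a different group on the carbonyl carbon, such as the 4-(methoxymethyl)piperidin-1-yl of compound 3.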